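A few compounds are considered here, and "the series" means these few. Any claim that something is new, unique, unknown or untested is made for them only; others in the source may bear on it.

Measured compounds:
compound 1, `Nc1scc(CN2CCN(c3ccc(Cl)cc3Cl)CC2)c1C(=O)c1ccc(Cl)cc1`: -11%
compound 2, `Nc1scc(CN2CCN(c3cccc(Cl)c3Cl)CC2)c1C(=O)c1ccc(Cl)cc1`: 3.2%
compound 3, `Nc1scc(CN2CCN(c3ccc(Cl)cc3F)CC2)c1C(=O)c1ccc(Cl)cc1`: -9.4%

In a functional assay on CHO cells with adenosine receptor A1 (Homo sapiens) as the target, read by cAMP accumulation and immunoassay, with a stated time of 6 min, tested at 0.1 uM (on this read-out higher numbers stand for a weaker effect at the one concentration tested and lower numbers for a stronger effect), compound 1 gives -11%, the lowest of the three numbers. The step of a number 1.6 percentage points higher from compound 1 to compound 3 (within the scatter) stays within the scatter, while the step of a number 14.2 percentage points higher from compound 1 to compound 2 (beyond the scatter) lies beyond it. Compound 4, `COc1ccc(N2CCN(Cc3csc(N)c3C(=O)c3ccc(Cl)cc3)CC2)cc1`, differs from compound 1 in one place: 4-methoxyphenyl in place of 2,4-dichlorophenyl on an amine nitrogen in a ring. The measured steps that bear on this are those that exchange the aryl group on the same ring nitrogen: a number 14.2 percentage points higher from compound 1 to compound 2 (beyond the scatter) and a number 12.6 percentage points lower from compound 2 to compound 3 (beyond the scatter), both modest and in opposite directions, so the whole series spans only a narrow band. Among the measured compounds shown here, no measured step puts a methoxy-bearing ring in place of a chlorinated one, so the direction of this change is not known from these data. Compound 4 is therefore expected to land near compound 1, with a step of a number 8 percentage points higher from compound 1 to compound 4 (within the scatter) that most likely stays within the scatter. The estimate for compound 4 is -3%, with a range from -16% to 10%.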

Compound 4, a percentage reported as activity, at one concentration (the size of the read-out at that concentration, not a potency): 0%
The estimate for compound 4 lay 3 percentage points below the measured number, within the range that was stated.
By their numbers in this assay, from the lowest: compounds 1, 3, 4 and 2 (each within the scatter of the next, the first and the last beyond it).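

In this assay, replacing the halogen-bearing aryl groups on the ring nitrogen with 4-methoxyphenyl gives a number 11 percentage points higher from compound 1 to compound 4 (beyond the scatter), while a number 9.4 percentage points higher from compound 3 to compound 4 (within the scatter) and a number 3.2 percentage points lower from compound 2 to compound 4 (within the scatter). This position therefore accepts an aryl group with no halogen and with a hydrogen-bond acceptor, and the numbers stay in the same narrow band. The change separates the new compound only from the 2,4-dichlorophenyl compound, and nothing shown explains that modest step.

From the compounds shown here alone, it remains open what a plain phenyl, a 4-hydroxyphenyl or a 4-aminophenyl group would give on this ring nitrogen. Going by these compounds, it is also open whether a methoxy group placed elsewhere on the aryl ring would give a number in the same band.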